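The source may hold more compounds than are shown below. What is called first, only, known or untested is meant among the compounds shown, and "the series" means these compounds.

The measured compounds:
Compound 1, `COc1nc(C)c(Nc2nc(Cl)cn([C@H](CO)C3CC3)c2=O)cc1C`, gives 88 nM in an assay on frontal cortex for displacement of a labelled ligand from corticotropin-releasing factor receptor 1 (Rattus norvegicus), with a stated time of 2 h; on this read-out higher numbers stand for weaker inhibition and lower numbers for stronger inhibition.
Compound 2, `COc1nc(C)c(Nc2nc(Cl)cn([C@H](COC(C)=O)C3CC3)c2=O)cc1C`, gives 5.3 nM in this assay.
Compound 3, `COc1nc(C)c(Nc2nc(Cl)cn([C@H](COC(=O)Nc3ccccc3)C3CC3)c2=O)cc1C`, gives 1.5 nM in this assay.

Compound 3 has the lowest number of the three in this assay. Its nearest neighbour is compound 2, with a 3.5-fold lower number from compound 2 to compound 3 (0.55 log units; beyond the scatter), and the gap to compound 1 is wider, with a 59-fold lower number from compound 1 to compound 3 (1.77 log units; beyond the scatter). Both of these steps are beyond the scatter, so compound 3 is the most potent of the three measured compounds.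

Compound 4, `COc1nc(C)c(Nc2nc(Cl)cn([C@H](COC(=O)Nc3ccccc3Cl)C3CC3)c2=O)cc1C`, differs from compound 3 in one place: chloro in place of hydrogen on an aromatic carbon. Within the data shown here, none of the measured steps touches this position. The steps of a 17-fold lower number from compound 1 to compound 2 (1.22 log units; beyond the scatter) and a 59-fold lower number from compound 1 to compound 3 (1.77 log units; beyond the scatter) concern what is attached to the oxygen on the saturated carbon, and a 3.5-fold lower number from compound 2 to compound 3 (0.55 log units; beyond the scatter) exchanges methyl for anilino on the carbonyl carbon. Among the measured compounds shown here, no measured pair varies a substituent on the phenyl ring itself, so there is no direct precedent here for the chloro.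

Given that, compound 4 is expected to stay close to compound 3 in this assay, with a 1.3-fold lower number from compound 3 to compound 4 (0.10 log units; within the scatter), a step not expected to exceed the scatter. The estimate for compound 4 is 1.2 nM, within a range from 0.4 nM to 4 nM.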

Compound 4, half-maximal inhibitory concentration: 1.5 nM
For compound 4 the middle estimate is 1.3-fold (0.10 log units) below the measured one, and the stated range covers the measured number.
By their numbers in this assay, from the lowest: compounds 3 and 4 (each within the scatter of the next); then compound 2; then compound 1.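

In this assay, chloro in place of hydrogen on an aromatic carbon, ortho to a large group, gives no change at the digits printed from compound 3 to compound 4 (within the scatter), so this place on the phenyl ring accepts a chlorine with no change that can be told from the scatter. The chlorine also leaves the distance to the two simpler esterified or free oxygen forms as it stood, with the (2-chlorophenyl)amino group in place of methyl giving a 3.5-fold lower number from compound 2 to compound 4 (0.55 log units; beyond the scatter) and the (2-chlorophenyl)carbamoyl group in place of hydrogen giving a 59-fold lower number from compound 1 to compound 4 (1.77 log units; beyond the scatter), so the ring can carry this substituent without losing what the carbamoyl group gained. Nothing at hand accounts for this lack of change.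

Since the chloro is the only substituent on this ring among the compounds shown, what a methoxy group, a nitrile or an amine would do at this place remains open, as does the effect of a chlorine elsewhere on the ring. From the compounds shown here alone, it is also open whether the ring is needed at all, or whether a longer saturated chain on the carbamoyl nitrogen would serve as well.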